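The source may report more compounds than this note shows. Statements on the series, on what has been measured and on what is new or still open speak of the compounds shown alone.

Three compounds have been measured so far:
compound 1 `CN(C)CCn1cnnc1-c1cc(Oc2ccc(NC(=O)N/N=C/c3c(Cl)cccc3Cl)cc2F)ccn1` gives 3320 nM in an ADME assay on WI-38 cells (Homo sapiens) for cytotoxicity, read by MTT assay, with a stated time of 72 h; on this read-out higher numbers stand for weaker inhibition and lower numbers for stronger inhibition;
compound 2 `COc1ccc(/C=N/NC(=O)Nc2ccc(Oc3ccnc(-c4nncn4CCN(C)C)c3)c(F)c2)c(OC)c1` gives 6630 nM;
compound 3 `CN(C)CCn1cnnc1-c1cc(Oc2ccc(NC(=O)N/N=C/c3ccccc3O[N+](=O)[O-])cc2F)ccn1` gives 6860 nM.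

Compound 2 stands second highest of these three numbers, yet neither neighbour is separated from it beyond the scatter: a 1.0-fold higher number from compound 2 to compound 3 (0.01 log units; within the scatter) and a 2.0-fold higher number from compound 1 to compound 2 (0.30 log units; within the scatter). Compound 4 `CN(C)CCn1cnnc1-c1cc(Oc2ccc(NC(=O)N/N=C/c3c(O)ccc4ccccc34)cc2F)ccn1` is not yet measured. Against compound 2 its change is 2-hydroxynaphthalen-1-yl in place of 2,4-dimethoxyphenyl on a carbon with a double bond to nitrogen. Going by the values given here, the steps that bear on this position are the two already named, both within the scatter, and the only step beyond it, a 2.1-fold higher number from compound 1 to compound 3 (0.32 log units; beyond the scatter), was modest. In this assay compound 4 is therefore expected to give 5500 nM, with a range from 2500 nM to 12000 nM. The expected step is a 1.2-fold lower number from compound 2 to compound 4 (0.08 log units; within the scatter), nothing beyond the scatter.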

Compound 4, half-maximal inhibitory concentration: 3250 nM
Compound 4: the middle estimate sits 1.7-fold (0.23 log units) above what was measured; low and high end bracket the measured number.
By their numbers in this assay, from the lowest: compounds 4, 1, 2 and 3 (each within the scatter of the next, the first and the last beyond it).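

In this assay, 2-hydroxynaphthalen-1-yl on this carbon gives a 2.0-fold lower number from compound 2 to compound 4 (0.31 log units; beyond the scatter) and a 2.1-fold lower number from compound 3 to compound 4 (0.32 log units; beyond the scatter), so compound 2 now has a step beyond the scatter, though a modest one. Against 2,6-dichlorophenyl the same group gives only a 1.0-fold lower number from compound 1 to compound 4 (0.01 log units; within the scatter), which leaves compound 4 and compound 1 together at the low end of the numbers. Nothing available explains these steps.

As far as these compounds go, whether the steps follow the hydroxyl or the second aromatic ring stays open. A 2-hydroxyphenyl or a naphthalen-1-yl group at this place would separate the two.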